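Swapping the chain end on a carboxy core of sulfamoyl anilines

The compounds below may be only part of what the source reports. "The series", "measured", "known", "first", "only" and "open" are said of these compounds alone.

The set starts from compound 1 `CCCCCCCCNc1ccc([N+](=O)[O-])cc1S(N)(=O)=O`, which in an assay on HEK293 cells for inhibition of solute carrier family 12 member 2 (Homo sapiens), read by fluorescence, with a stated time of 30 min, tested at 100 uM (on this read-out lower numbers stand for a weaker effect and higher numbers for a stronger effect at the one concentration tested), gives 5.8%. Compound 2 `CC(C)(C)CCNc1ccc([N+](=O)[O-])cc1S(N)(=O)=O` keeps the core of compound 1 and changes only the chain: tert-butyl in place of hexyl on a saturated chain carbon, two bonds along the chain from a nitrogen on an aromatic ring. In this assay compound 2 gives 14.5%, so that a number 8.7 percentage points higher from compound 1 to compound 2 (within the scatter). Compound 3 `CCCCCCCCNc1ccc(C(=O)O)cc1S(N)(=O)=O` keeps the octyl chain of compound 1 but carries a different core: carboxy in place of nitro on an aromatic carbon. In this assay compound 3 gives 24%, which means a number 18.2 percentage points higher from compound 1 to compound 3 (beyond the scatter). Among the three measured compounds, the number for compound 3 is the highest, though its distance to compound 2 lies within the scatter and only its distance to compound 1 lies beyond it.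

Compound 4 `CC(C)(C)CCNc1ccc(C(=O)O)cc1S(N)(=O)=O` has not been measured. It stands to compound 3 as compound 2 stands to compound 1, with the same change at the same place: tert-butyl in place of hexyl on a saturated chain carbon, two bonds along the chain from a nitrogen on an aromatic ring. Within the data shown here, the only guide for the step from compound 3 to compound 4 is the earlier one, which stayed within the scatter. Compound 4 is therefore expected to land near or a little above compound 3, with the expected step being a number 7 percentage points higher from compound 3 to compound 4 (within the scatter), because the earlier change gave a number 8.7 percentage points higher from compound 1 to compound 2 (within the scatter). Whether the chain change acts the same on the carboxy core as on the nitro core is not known from these three compounds, so the range is kept wide. The estimate for compound 4 in this assay is 31%, with a likely span from 16% to 46%.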

Compound 4, a percentage reported as inhibition, at one concentration (the size of the read-out at that concentration, not a potency): 5.1%
For compound 4 the middle estimate is 25.9 percentage points above the measured one; the measured number lies below the stated range.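

On the carboxy core, the swap of hexyl for tert-butyl gave a number 18.9 percentage points lower from compound 3 to compound 4 (beyond the scatter) in this assay, and the two steps for this one change do not agree: the same change on two cores in this assay, a number 8.7 percentage points higher (within the scatter) from compound 1 to compound 2 and a number 18.9 percentage points lower (beyond the scatter) from compound 3 to compound 4, 27.6 percentage points apart, beyond the scatter of two such steps. Read the other way, carboxy in place of nitro gave a number 9.4 percentage points lower from compound 2 to compound 4 (within the scatter) with the tert-butyl end, and this too differs from the same core change made with the hexyl end: the same change on two cores in this assay, a number 18.2 percentage points higher (beyond the scatter) from compound 1 to compound 3 and a number 9.4 percentage points lower (within the scatter) from compound 2 to compound 4, 27.6 percentage points apart, beyond the scatter of two such steps. This shows that, among these four compounds, the step seen on one core did not carry over to the other, so the chain change and the core change cannot be treated as separate, additive steps; it does not show why the two cores part, and with a single pair of cores and one tested concentration it gives no rule for any further core.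

The compounds shown leave open how other chain ends, such as a cyclohexyl ring or a shorter straight chain, would behave on the nitro and carboxy cores. They also leave open whether an amide or a nitrile in place of the carboxy group would follow the nitro core, the carboxy core or neither.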